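Chloro in Place of Fluoro on the Shared Core

The source may hold more compounds than are shown below. What is called first, only, known or untested is meant among the compounds shown, and "the series" means these compounds.

Measured compounds:
compound 1 `O=C(/C=C\Nc1ccc(Cl)cc1)c1cn(-c2ccccc2)nc1-c1ccc(F)cc1`: 4600 nM
compound 2 `O=C(/C=C\Nc1ccc(O)cc1)c1cn(-c2ccccc2)nc1-c1ccc(F)cc1`: 1900 nM
compound 3 `COc1ccc(N/C=C\C(=O)c2cn(-c3ccccc3)nc2-c2ccc(F)cc2)cc1`: 3200 nM

In a functional assay on HT-29 cells (Homo sapiens) for antiproliferative activity, read by MTT assay, with a stated time of 48 h (on this read-out lower numbers stand for stronger inhibition and higher numbers for weaker inhibition), compound 1 gives 4600 nM, the highest of the three numbers and therefore the weakest inhibition seen so far. Its nearest neighbour is compound 3, with a 1.4-fold lower number from compound 1 to compound 3 (0.16 log units; within the scatter). Its furthest is compound 2, with a 2.4-fold lower number from compound 1 to compound 2 (0.38 log units; beyond the scatter). The remaining pair shows a 1.7-fold higher number from compound 2 to compound 3 (0.23 log units; within the scatter). All three of these steps concern the same aromatic ring, the one carried by the nitrogen, and they leave the rest of the shared core untouched.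

Compound 4 `O=C(/C=C\Nc1ccc(Cl)cc1)c1cn(-c2ccccc2)nc1-c1ccc(Cl)cc1` has not yet been measured in this assay. It differs from compound 1 in one place: chloro in place of fluoro on an aromatic carbon. Among the compounds with values here, none of the measured steps touches this ring, so no measured step bears directly on the change; the measured steps only show that small swaps elsewhere on the core moved the number by modest amounts at most. The step to compound 4 is therefore expected to be a 1.2-fold lower number from compound 1 to compound 4 (0.06 log units; within the scatter), within the scatter of repeated measurements. Compound 4 is estimated at 4000 nM, with a range from 1500 nM to 11000 nM.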

Compound 4, half-maximal inhibitory concentration: 4650 nM
Compound 4: the middle estimate sits 1.2-fold (0.07 log units) below what was measured, within the range that was stated.
By their numbers in this assay, from the lowest: compounds 2, 3, 1 and 4 (each within the scatter of the next, the first and the last beyond it).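

The swap of 4-fluorophenyl for 4-chlorophenyl is the first change shown on this ring, as every earlier step concerned the ring carried by the nitrogen, and in this assay it gives a 1.0-fold higher number from compound 1 to compound 4 (0.00 log units; within the scatter). For this pair, then, chloro can stand in place of fluoro on this aromatic carbon with no difference beyond the scatter of repeated measurements, although this is one exchange between two halogens, made on a compound that also carries chloro on the other ring. No measurement presented here accounts for why the two compounds read alike.

The compounds shown do not tell whether this position would accept a group of another kind, such as an amine, a carboxylic acid or a nitrile, in place of the halogen, or whether the ring would read the same with only hydrogen there. They also leave open whether the same exchange of fluoro for chloro would read alike in compounds that carry hydroxy or methoxy on the other ring, as compound 2 and compound 3 do.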